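This account rests on a few compounds, and the source may have more. Where it says the series, first, only, none or still open, it means among the compounds named here.

Working notes on the series.

Compound 1, `CC1(C)N([O])C(c2ccccc2O)=[N+]([O-])C1(C)C`, and compound 2, `CC1(C)N([O])C(c2cccc(O)c2)=[N+]([O-])C1(C)C`, carry the same atoms joined differently; the difference between the two cores is not broken down here. In a physicochemical assay for lipophilicity (a lower number here means a more polar compound, a higher number a more lipophilic compound), compound 1 gives 1.17, and in this assay compound 2 gives 1.14; the two values lie within the scatter of each other.

Compound 3, `CC1(C)N([O])C(c2ccccc2[N+](=O)[O-])=[N+]([O-])C1(C)C`, is obtained from compound 1 by nitro in place of hydroxy on an aromatic carbon. In this assay compound 3 gives 0.909. The measured step is a number 0.26 log units lower from compound 1 to compound 3 (within the scatter), so the change barely moves the read-out in this pair.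

Compound 4, `CC1(C)N([O])C(c2cccc([N+](=O)[O-])c2)=[N+]([O-])C1(C)C`, is the matching change on compound 2: nitro in place of hydroxy on an aromatic carbon. Among the measured compounds shown here, it is the same kind of change as the one from compound 1 to compound 3, not the same, as the place differs: ortho to a large group in the measured pair, meta to a large group in compound 4. Only these two instances of the change occur among the compounds shown, and only one is measured, so the expectation for compound 4 rests on a single pair.

Because a number 0.26 log units lower from compound 1 to compound 3 (within the scatter) is within the scatter, the step expected in this assay is a number 0.26 log units lower from compound 2 to compound 4 (within the scatter), of about the same size. Compound 4 is expected in this assay to give about 0.88, estimated to fall between 0.6 and 1.2. The measurement of compound 4 will show whether the change at the new place behaves in the same way.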

Compound 4, partition coefficient: 1.64
The estimate for compound 4 lay 0.76 log units below the measured number; measured number outside the range, above it.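

In this assay the new step is a number 0.50 log units higher from compound 2 to compound 4 (beyond the scatter) and the same replacement on the other core gave a number 0.26 log units lower from compound 1 to compound 3 (within the scatter) in the earlier pair, so nitro in place of hydroxy on an aromatic carbon did not carry over from one core to the other as a step of fixed size. This shows only that the outcome of the change cannot be read across between these two pairs; it does not show a rule for any other place or core, and the two pairs differ in the place of the change, meta to a large group in compound 4, as well as in the arrangement of the starting compound. Nothing measured in the series accounts for the difference between the two pairs.

The compounds shown leave open whether the step seen at this place belongs to nitro alone or would also appear with another group in place of hydroxy on the same aromatic carbon, such as an amine or a carboxylic acid. Among the compounds shown here, they also leave open how far the result holds more widely, with each place represented by a single pair and nitro the only entering group.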